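A Methoxy for Two Methyls on the Benzyl Ether

A few compounds are considered here, and "the series" means these few. Any claim that something is new, unique, unknown or untested is made for them only; others in the source may bear on it.

Of the compounds shown here, three sharing one core have been measured in a functional assay on Mahlavu cells (Homo sapiens) for antiproliferative activity, read by sulforhodamine B assay, with a stated time of 72 h; a lower number here means a stronger inhibitor, a higher number a weaker inhibitor. Compound 1 `FC(F)(F)c1ccc(CN2CCN(Cc3cc(-c4ccc(OCc5ccccc5)cc4)on3)CC2)cc1` gives 11700 nM. Compound 2 `Cc1cc(C)cc(COc2ccc(-c3cc(CN4CCN(Cc5ccc(C(F)(F)F)cc5)CC4)no3)cc2)c1` gives 6000 nM, and compound 3 `FC(F)(F)c1ccc(CN2CCN(Cc3cc(-c4ccc(OCc5ccccc5Cl)cc4)on3)CC2)cc1` gives 3200 nM. On these numbers compound 2 stands second highest of the three: the step of a 2.0-fold lower number from compound 1 to compound 2 (0.29 log units; within the scatter) is within the scatter, as is the step of a 1.9-fold lower number from compound 2 to compound 3 (0.27 log units; within the scatter), while the step of a 3.7-fold lower number from compound 1 to compound 3 (0.56 log units; beyond the scatter) is beyond it, though modest.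

Compound 4 `COc1ccc(COc2ccc(-c3cc(CN4CCN(Cc5ccc(C(F)(F)F)cc5)CC4)no3)cc2)cc1` has not yet been measured in this assay. Its difference from compound 2 is 4-methoxyphenyl in place of 3,5-dimethylphenyl on a saturated chain carbon bound to an oxygen on an aromatic ring. The measured steps that bear on this place are the step of a 2.0-fold lower number from compound 1 to compound 2 (0.29 log units; within the scatter) and the step of a 1.9-fold lower number from compound 2 to compound 3 (0.27 log units; within the scatter), both within the scatter, so exchanging one substituted phenyl for another on the saturated chain carbon bound to an oxygen on an aromatic ring has so far not moved the number beyond the usual spread. Compound 4 is therefore expected to show a step of no change at the digits printed from compound 2 to compound 4 (within the scatter), staying within the scatter. The estimate for compound 4 in this assay is 6000 nM, with a range from 2500 nM to 14000 nM.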

Compound 4, half-maximal inhibitory concentration: 4900 nM
The estimate for compound 4 lay 1.2-fold (0.09 log units) above the measured number; measured number inside the range.
By their numbers in this assay, from the lowest: compounds 3, 4, 2 and 1 (each within the scatter of the next, the first and the last beyond it).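

In this assay, a group carrying an oxygen and one hydrogen-bond acceptor, where 3,5-dimethylphenyl carries neither, gives a 1.2-fold lower number from compound 2 to compound 4 (0.09 log units; within the scatter) at the same count of heavy atoms, so this exchange does not separate compound 4 from compound 2. The same holds against the chlorinated group, with a 1.5-fold higher number from compound 3 to compound 4 (0.19 log units; within the scatter) showing that 4-methoxyphenyl and 2-chlorophenyl cannot be told apart at this place. Among the compounds shown here, the unsubstituted phenyl is the one comparison that does separate, with a 2.4-fold lower number from compound 1 to compound 4 (0.38 log units; beyond the scatter) beyond the scatter though modest, which makes compound 4 the second substituted compound after compound 3 to stand apart from compound 1, while compound 2 goes against this pattern with a 2.0-fold lower number from compound 1 to compound 2 (0.29 log units; within the scatter) within the scatter. Nothing available here offers an explanation for these steps.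

The compounds shown leave open whether an amine or a carboxylic acid on this benzyl group would move the number further than the methoxy and chloro groups do. They also leave open whether a longer chain in place of the single saturated carbon bound to the oxygen would keep the numbers in this range.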